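A few compounds are considered here, and "the series" means these few. Any claim that something is new, unique, unknown or untested is made for them only; others in the source may bear on it.

Measured in a functional assay on HL-60 cells (Homo sapiens) for cytotoxicity, read by MTT assay, with a stated time of 96 h; a higher number here means a weaker inhibitor, a lower number a stronger inhibitor:
Compound 1 `CC[C@H](N)C(=O)N[C@@H]1C(=O)N2[C@@H](CC[C@@H]1CCN)CC[C@H]2C(=O)NC(c1ccccc1)c1ccccc1`: 25000 nM
Compound 2 `CC[C@H](N)C(=O)N[C@@H]1C(=O)N2[C@@H](CC[C@@H]1CCO)CC[C@H]2C(=O)NC(c1ccccc1)c1ccccc1`: > 100000 nM (a limit)

Compound 2 reads > 100000 nM, which is a limit of this assay and not a number. Its true position is therefore open on one side.

The next compound is compound 3 `CC[C@H](N)C(=O)N[C@@H]1C(=O)N2[C@@H](CC[C@@H]1CCNC(=O)NCc1ccccc1)CC[C@H]2C(=O)NC(c1ccccc1)c1ccccc1`, which has (benzylcarbamoyl)amino in place of hydroxy on a saturated chain carbon, two bonds along the chain from a saturated ring carbon.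

Within the data shown here, one measured step bears on this change. It is an at least 4.0-fold higher number from compound 1 to compound 2 (0.60 log units; beyond the scatter), beyond the scatter, and it swaps hydroxy for amino at the same place. Compound 3 keeps a nitrogen on that chain carbon, as compound 1 does. Read in reverse, the step from compound 1 points to an expected lower number in this assay, of modest size. Among the measured compounds shown here, no measured compound carries the entering group, so the range stays wide and a reading at the limit remains possible.

The expected change is an at least 3.3-fold lower number from compound 2 to compound 3 (0.52 log units; beyond the scatter).

Compound 3 is estimated at 30000 nM, with an expected range of 7000 nM to 100000 nM.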

Compound 3, half-maximal inhibitory concentration: 83300 nM
Estimate against measurement, compound 3: 2.8-fold (0.44 log units) below, and the stated range covers the measured number.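

In this assay, putting benzylcarbamoyl on the amine nitrogen gives a 3.3-fold higher number from compound 1 to compound 3 (0.52 log units; beyond the scatter), so the free amine of compound 1 holds the lowest number of the three compounds, while a group of this size on that nitrogen still leaves a measurable value. Compound 2 stays a limit of this assay and not a number: the limit of > 100000 nM in this assay, at which 1 of the 3 values shown sits. Against that limit the change from hydroxy to (benzylcarbamoyl)amino reads an at least 1.2-fold lower number from compound 2 to compound 3 (0.07 log units; that floor lies within the scatter), and as that floor lies within the scatter, no order between these two compounds can be stated.

These notes do not separate the part played by the carbonyl of the benzylcarbamoyl group from that of its benzyl ring, so the higher number of compound 3 cannot be assigned to either. As far as these compounds go, it also stays open whether an acetyl group on the same nitrogen, a dimethylamine at the chain end or a longer chain carrying the amine would remain close to compound 1 or move towards compound 3.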